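Para-dimethylamino anilide of the pyridine acid core

The compounds below may be only part of what the source reports. "The series", "measured", "known", "first", "only" and "open" are said of these compounds alone.

Among the measured compounds shown here, compound 1 `O=C(Nc1ccccc1)c1ccc(C(=O)O)nc1` stands second highest of the three numbers measured so far in an assay on isolated protein (Gallus gallus) for inhibition of transmembrane prolyl 4-hydroxylase (Homo sapiens) (on this read-out higher numbers stand for weaker inhibition and lower numbers for stronger inhibition), where compound 1 gives 26500 nM. Compound 2 `O=C(Nc1ccccc1F)c1ccc(C(=O)O)nc1` gives 11000 nM and compound 3 `CCOc1ccccc1NC(=O)c1ccc(C(=O)O)nc1` gives 32900 nM; the step of a 2.4-fold lower number from compound 1 to compound 2 (0.38 log units; beyond the scatter) is modest, the step of a 1.2-fold higher number from compound 1 to compound 3 (0.09 log units; within the scatter) stays within the scatter, and a 3.0-fold higher number from compound 2 to compound 3 (0.48 log units; beyond the scatter) is again modest. Compound 4 `CN(C)c1ccc(NC(=O)c2ccc(C(=O)O)nc2)cc1` differs from compound 1 by dimethylamino in place of hydrogen on an aromatic carbon. For the measured compounds named here, no measured step places a dimethylamino group on the anilide ring, and no measured step puts any group para to a large group, so the two substitutions seen so far bear on the change only loosely: each moved this assay by a modest amount at most, in opposite directions. The expected step is therefore none beyond the scatter, a 1.3-fold lower number from compound 1 to compound 4 (0.12 log units; within the scatter), with the wide uncertainty that follows from the lack of a direct precedent. Compound 4 is estimated at 20000 nM in this assay, expected between 7000 nM and 60000 nM.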

Compound 4, half-maximal inhibitory concentration: 4100 nM
Estimate against measurement, compound 4: 4.9-fold (0.69 log units) above; the measured number lies below the stated range.
By their numbers in this assay, from the lowest: compound 4; then compound 2; then compounds 1 and 3 (each within the scatter of the next).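

In this assay, dimethylamino para to a large group gives a 6.5-fold lower number from compound 1 to compound 4 (0.81 log units; beyond the scatter), a larger step than either fluoro or ethoxy gave from compound 1. Among the compounds shown here, this is the first sign that a substituent on this aromatic ring can lower the number by more than the earlier changes did, and here the entering group has no ring and no net charge. Nothing measured here accounts for the size of this step.

The compounds shown do not separate the effect of the group from that of its place, as fluoro, ethoxy and dimethylamino each appear at only one place on the ring. Also open, from the compounds shown here alone, is whether an unsubstituted amine, a methoxy group or a longer chain such as diethylamino at this same place would follow compound 4.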